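Lengthening the chain: from ethyl to propyl on the amide

The source may report more compounds than this note shows. Statements on the series, on what has been measured and on what is new or still open speak of the compounds shown alone.

In a functional assay on CHO cells for positive allosteric modulation of muscarinic acetylcholine receptor M5 (Homo sapiens), read by calcium flux (on this read-out higher numbers stand for larger maximal responses and lower numbers for smaller maximal responses), compound 1 `CCN(Cc1ccccc1Cl)C(=O)C1CCN(S(=O)(=O)c2ccc3[nH]ncc3c2)CC1` gives 78%, and compound 2 `CCN(Cc1ccccc1C(F)(F)F)C(=O)C1CCN(S(=O)(=O)c2ccc3[nH]ncc3c2)CC1` gives 96%. Among the measured compounds shown here, compound 2 stands highest of the two numbers measured so far; the only recorded step, a number 18 percentage points higher from compound 1 to compound 2 (beyond the scatter), came from a trifluoromethyl in place of chloro on an aromatic carbon.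

Compound 3 `CCCN(Cc1ccccc1C(F)(F)F)C(=O)C1CCN(S(=O)(=O)c2ccc3[nH]ncc3c2)CC1` differs from compound 2 by methyl in place of hydrogen on a saturated chain carbon, two bonds along the chain from an amide-type nitrogen. For the measured compounds named here, this change sits on the chain at the amide, far from the aromatic carbon that was changed in the one measured step, so no measured step bears directly on it. With no guide from the shown data, the expected step of a number 4 percentage points lower from compound 2 to compound 3 (within the scatter) is none beyond the scatter. For compound 3 the estimated value in this assay is therefore 92%, expected to fall between 76% and 106%.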

Compound 3, largest response reached (reported as percent of maximum), in percent of the reference or control that the assay uses: 94%
Beside the measured number, compound 3's estimate is 2 percentage points below it; the measured number falls inside the stated range.
By their numbers in this assay, from the lowest: compound 1; then compounds 3 and 2 (each within the scatter of the next).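

In this assay, methyl in place of hydrogen on a saturated chain carbon, two bonds along the chain from an amide-type nitrogen, gives a number 2 percentage points lower from compound 2 to compound 3 (within the scatter), so this change from ethyl to propyl separates the two compounds by no more than ordinary assay variation. The earlier step, a number 18 percentage points higher from compound 1 to compound 2 (beyond the scatter), showed a change on an aromatic carbon moving the maximal response, whereas this first step on the amide chain shows that one added carbon can be accommodated without a change beyond the scatter. No measured evidence here explains this result.

Still open, as far as these compounds go, is whether a longer chain such as butyl, or a branched group such as isopropyl, would keep the response at this level. From the compounds shown here alone, it is also open how a chain ending in an amine or a carboxylic acid would behave at this position.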